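The source may report more compounds than this note shows. Statements on the series, on what has been measured and on what is new or still open speak of the compounds shown alone.

Measured compounds in a functional assay on NCI-H460 cells (Homo sapiens) for inhibition, read by MTT assay, with a stated time of 72 h; on this read-out lower numbers stand for stronger inhibition and higher numbers for weaker inhibition:

Compound 1, `CN(C)C(=S)SCC(CSC(=S)N(C)C)C(=O)c1ccc(F)cc1`: 1210 nM

Compound 2, `CN(C)C(=S)SCC(CSC(=S)N(C)C)C(=O)c1ccccc1F`: 920 nM

Compound 2 holds the lowest of the two numbers in this assay, but its separation from compound 1 is small: the step from compound 1 to compound 2 is a 1.3-fold lower number from compound 1 to compound 2 (0.12 log units; within the scatter), so the two compounds cannot be told apart on these data. That step concerns only where the fluorine sits on the aromatic ring attached to the carbonyl carbon.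

Compound 3, `COc1cccc(C(=O)C(CSC(=S)N(C)C)CSC(=S)N(C)C)c1`, has not been measured. The change is 3-methoxyphenyl in place of 2-fluorophenyl on a carbonyl carbon. For the measured compounds named here, the only measured step in this assay, the one from compound 1 to compound 2, moved a fluorine within the same ring and stayed within the scatter; it says little about swapping a fluorine for a methoxy group. Going by the values given here, no measured pair bears directly on this change, so the expectation rests on the fact that the one aromatic-ring alteration seen so far produced no movement beyond the scatter.

Compound 3 is therefore expected to give about 1100 nM in this assay, with a plausible range from 400 nM to 3000 nM, which corresponds to an estimated step of a 1.2-fold higher number from compound 2 to compound 3 (0.08 log units; within the scatter), essentially no change beyond the scatter.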

Compound 3, half-maximal inhibitory concentration: 1240 nM
The estimate for compound 3 lay 1.1-fold (0.05 log units) below the measured number; low and high end bracket the measured number.
By their numbers in this assay, from the lowest: compounds 2, 1 and 3 (each within the scatter of the next).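

The new result adds a change of a different kind, since a methoxy group now replaces fluorine on the aromatic ring rather than fluorine simply sitting elsewhere on it. In this assay, 3-methoxyphenyl in place of 2-fluorophenyl on the carbonyl carbon gives a small step (a 1.3-fold higher number from compound 2 to compound 3 (0.13 log units; within the scatter)), and 3-methoxyphenyl in place of 4-fluorophenyl gives a smaller one (a 1.0-fold higher number from compound 1 to compound 3 (0.01 log units; within the scatter)), so across these three compounds this position shows no movement beyond the scatter, even with a different group and a hydrogen-bond acceptor present. Nothing measured here offers a reason for this flat result.

These compounds leave open whether the position stays as flat with a group of another kind, such as an amine or a carboxylic acid on the ring, or a longer chain in place of the ring. They also cannot show how much the rest of the molecule contributes, as the shared core stays the same in all three compounds.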